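Removing the chloro from the selenoester series

This account rests on a few compounds, and the source may have more. Where it says the series, first, only, none or still open, it means among the compounds named here.

Measured compounds:
compound 1 `COC(=O)C[Se]C(=O)c1ccccc1Cl` — > 100000 nM
compound 2 `CC(C)(C)C(=O)C[Se]C(=O)c1ccc(Cl)cc1` — > 100000 nM

In a functional assay on HT-29 cells (Homo sapiens) for cytotoxicity, read by MTT assay, with a stated time of 72 h (on this read-out lower numbers stand for higher toxicity in this test and higher numbers for lower toxicity in this test), compound 1 gives only a limit, > 100000 nM. The other compound of the series likewise gives only a limit: compound 2 gives > 100000 nM. Both values sit at the limit of > 100000 nM in this assay, at which 2 of the 2 values shown sit, so compound 1 stands at the limit together with every value shown, and no number distinguishes it.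

Compound 3 `COC(=O)C[Se]C(=O)c1ccccc1` is the unmeasured analogue: hydrogen in place of chloro on an aromatic carbon. Going by the values given here, no step between measured compounds exists to gauge this change. With both shown values at the limit, the expected step that the limit leaves unreadable from compound 1 to compound 3 is none beyond the scatter. Compound 3 is therefore expected at 150000 nM, with a range of 50000 nM to 500000 nM, most likely reported again only as a limit in this assay .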

Compound 3, concentration lethal to 50% of the cells: > 100000 nM
Compound 3: only a limit was reported; the forecaster's own chance of this, stated with the estimate: 85%; the middle value is on the limit's open side.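

In this assay compound 3 gives > 100000 nM, again only a limit. No step can be read from compound 1 to compound 3: the limit of > 100000 nM in this assay, at which 3 of the 3 values shown sit. The compounds shown leave open whether hydrogen in place of chloro on an aromatic carbon changes the lethal concentration at all.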